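The source may hold more compounds than are shown below. What is called first, only, known or untested is meant among the compounds shown, and "the series" means these compounds.

Among the measured compounds shown here, in a functional assay on MCF7 cells (Homo sapiens) for antiproliferative activity, read by CCK-8 assay, with a stated time of 72 h (on this read-out higher numbers stand for weaker inhibition of growth and lower numbers for stronger inhibition of growth), compound 2 `CCC1C(=O)N(C)c2cnc(-n3ccc4cc(C(=O)NC(C)C)ccc43)nc2N1c1ccn(C)n1` gives 8420 nM, the higher of the two numbers so far. That is weaker, by more than the usual scatter, than compound 1 `CC[C@@H]1C(=O)N(C)c2cnc(-n3ccc4cc(C(N)=O)ccc43)nc2N1C1CCCC1` at 1830 nM. Compound 3 `CCC1C(=O)N(C)c2cnc(-n3ccc4cc(C(=O)NC)ccc43)nc2N1c1ccn(C)n1` carries methyl in place of isopropyl on an amide-type nitrogen. For the measured compounds named here, no measured pair shows this change alone, so only a small shift towards stronger inhibition is expected in this assay, probably within the scatter. The estimated step is a 1.7-fold lower number from compound 2 to compound 3 (0.23 log units; within the scatter). For compound 3 the expected value is 5000 nM, with a range of 2000 nM to 12000 nM.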

Compound 3, concentration for 50% growth inhibition: 35400 nM
For compound 3 the middle estimate is 7.1-fold (0.85 log units) below the measured one, outside the stated range (above it).
By their numbers in this assay, from the lowest: compound 1; then compound 2; then compound 3.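

In this assay, the step from isopropyl to methyl on this amide-type nitrogen is a 4.2-fold higher number from compound 2 to compound 3 (0.62 log units; beyond the scatter) and goes with weaker inhibition of growth, beyond the scatter. This single pair shows that the group at this position affects the read-out, and that here the larger of the two groups gives the stronger inhibition. Nothing measured here explains the shift.

Among the compounds shown here, with only two groups compared at this position, no trend with size can be drawn. Going by these compounds, it remains open how an ethyl group, a longer chain or a chain ending in an amine would behave here.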